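Swapping 4-aminophenyl for 3-(methylamino)propyl: working notes

This account rests on a few compounds, and the source may have more. Where it says the series, first, only, none or still open, it means among the compounds named here.

Values so far in a functional assay on SK-BR-3 cells (Homo sapiens) for cytotoxicity, read by MTT assay, with a stated time of 72 h (a higher number here means a weaker inhibitor, a lower number a stronger inhibitor), for this series:
- compound 1 `N[C@H]1CC[C@H](Nc2c(C(=O)NCc3ccc(Oc4ccccc4)cc3)nc(Br)c3cccnc23)CC1` gives "not determined" (no result reported)
- compound 2 `Nc1ccc(Nc2c(C(=O)NCc3ccc(F)cc3)nc(Br)c3cccnc23)cc1` gives 4000 nM
- compound 3 `COC(=O)c1nc(Br)c2cccnc2c1N[C@H]1CC[C@H](N)CC1` gives "not determined" (no result reported)

For the measured compounds named here, compound 2 at 4000 nM is the only number available, since neither of the other two compounds has a reported result. Going by the values given here, it therefore cannot be ranked against anything, and the series has no measured step between compounds to give a scale for structural change.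

The next compound is compound 4 `CNCCCNc1c(C(=O)NCc2ccc(F)cc2)nc(Br)c2cccnc12`, still to be measured in this assay. Its difference from compound 2 is 3-(methylamino)propyl in place of 4-aminophenyl on a nitrogen on an aromatic ring and amounts to 3-(methylamino)propyl in place of 4-aminophenyl on a nitrogen on an aromatic ring. A ring is thus exchanged for an open chain, while the rest of the structure stays the same.

With a single value as the anchor, the expectation is necessarily loose. The expected 1.6-fold lower number from compound 2 to compound 4 (0.20 log units; within the scatter) is no change beyond the usual scatter, with only a slight lean toward a stronger inhibitor. Among the compounds with values here, the range is kept wide, as no measured pair tests this exchange. For compound 4 the estimated value is 2500 nM, with an expected range from 600 nM to 10000 nM as the likely outcome.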

Compound 4, half-maximal inhibitory concentration: 1000 nM
The estimate for compound 4 lay 2.5-fold (0.40 log units) above the measured number, and the stated range covers the measured number.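

In this assay the substituent on a nitrogen on an aromatic ring now has its first measured step, and swapping 4-aminophenyl for 3-(methylamino)propyl gives a 4.0-fold lower number from compound 2 to compound 4 (0.60 log units; beyond the scatter) in this pair. The six-membered aromatic ring of 4-aminophenyl is therefore not needed to keep a measurable cytotoxic effect here, as an open chain with no ring gives the lower number of the two, even though the hydrogen-bond donor and acceptor counts of the two groups are the same. Nothing in hand accounts for the size or direction of this step.

From the compounds shown here alone, what remains open is which feature of the exchange carries the step, since ring loss, chain length and the type of amine all change together in this single pair. A 3-aminopropyl or 3-(dimethylamino)propyl group would test the amine on the same chain, while 3-hydroxypropyl would replace the amine altogether and a longer chain such as 4-(methylamino)butyl would vary the chain length.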